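Methoxy to Hydroxy on the Aryl Group of Compound 2

The compounds below may be only part of what the source reports. "The series", "measured", "known", "first", "only" and "open" are said of these compounds alone.

The series shares one core carrying a nitrile-bearing side chain and a 3-methoxy-5-methylphenyl group, and was tested in a functional assay on HOP-62 cells (Homo sapiens) for inhibition, read by sulforhodamine B assay, with a stated time of 48 h; on this read-out higher numbers stand for weaker inhibition of growth and lower numbers for stronger inhibition of growth. Compound 1 `COc1cc(C)cc(-c2c(-c3ccnc(-c4ccc(N(C)C)cc4)c3)cnn2CC#N)c1` gives no number in this assay: its result is a limit, > 100000 nM, that is, (the limit of > 100000 nM in this assay, at which 1 of the 3 values shown sits). Compound 2 `COc1cc(C)cc(-c2nn(CC#N)cc2-c2ccnc(-c3ccc(N(C)C)cc3)c2)c1` differs from compound 1 in how the two aryl groups are arranged on the core; in this assay compound 2 gives 18700 nM. Compound 3 `COc1cc(C)cc(-c2nn(CC#N)cc2-c2ccc(-c3cccc(C(C)=O)c3)nc2)c1`, with a different pyridine substituent, gives 36900 nM; the gap between compound 2 and compound 3 falls within the usual scatter, so the two cannot be told apart on these numbers.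

Compound 4 `Cc1cc(O)cc(-c2nn(CC#N)cc2-c2ccnc(-c3ccc(N(C)C)cc3)c2)c1` is the next step from compound 2. The change is hydrogen in place of methyl on an oxygen on an aromatic ring. Among the compounds with values here, no measured pair in this set shows what such a change does, so the expected step in this assay is small and with no clear direction, none beyond the scatter. Compound 4 is therefore estimated at 16000 nM, with a likely range from 4000 nM to 60000 nM. The expected step of a 1.2-fold lower number from compound 2 to compound 4 (0.07 log units; within the scatter) is essentially flat.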

Compound 4, concentration for total growth inhibition: 23400 nM
For compound 4 the middle estimate is 1.5-fold (0.17 log units) below the measured one; the range from low to high includes it.
By their numbers in this assay, from the lowest: compounds 2, 4 and 3 (each within the scatter of the next). At a limit, above all of these: compound 1.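

Within the data shown here, this is the first pair in the set that differs in one place, and in this assay the change from methoxy to hydroxy gives a 1.3-fold higher number from compound 2 to compound 4 (0.10 log units; within the scatter). Compound 2 and compound 4 therefore cannot be told apart, and on these numbers the methyl on this oxygen, within the 3-methoxy-5-methylphenyl group, can give way to hydrogen with no step beyond the scatter. Nothing in the data on hand speaks to why this change leaves the reading so flat.

Going by these compounds, the pair covers only one background, so whether hydrogen in place of methyl on this oxygen gives a similarly small step with the pyridine substituent of compound 3, or with the aryl arrangement of compound 1, remains open. Also unsettled is how this position responds to groups other than methoxy and hydroxy, such as an ethoxy or other longer chain on the oxygen, or an amine or a carboxylic acid in its place on the aromatic ring.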